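Side-chain change on a weak electroshock compound

This account rests on a few compounds, and the source may have more. Where it says the series, first, only, none or still open, it means among the compounds named here.

Compound 1 `COCC(C(=O)N1CCN(c2cccc(C(F)(F)F)c2)CC1)N1C(=O)CCC1=O`: 25%
Compound 2 `CC(C(=O)N1CCN(c2ccc(Cl)cc2)CC1)N1C(=O)CCC1=O`: 100%
Compound 3 `CC(C(=O)N1CCN(c2ccc(C(F)(F)F)cc2)CC1)N1C(=O)CCC1=O`: 25%

In a functional assay on the whole organism (strain Swiss) with Mus musculus as the target, in the maximal electroshock model, with a stated time of 0.25 h, at a dose of 300 mg/kg by the intraperitoneal route (on this read-out higher numbers stand for a stronger effect at the one dose given and lower numbers for a weaker effect), compound 1 gives 25%, level with compound 3 at the digits printed; together they stand lowest of the three, while compound 2 is the highest. Among the measured compounds shown here, the one measured step, a number 75 percentage points lower from compound 2 to compound 3 (beyond the scatter), lies on the aromatic ring. Compound 4 `CCC(C(=O)N1CCN(c2cccc(C(F)(F)F)c2)CC1)N1C(=O)CCC1=O` differs from compound 1 in another place: methyl in place of methoxy on a saturated chain carbon, two bonds along the chain from an amide-type nitrogen in a ring and a carbonyl carbon. No measured step touches this chain carbon, so nothing shown bears directly on the change, and the expectation in this assay is a step of no change at the digits printed from compound 1 to compound 4 (within the scatter), within the scatter. Compound 4 is therefore estimated at 25%, with a range from 0% to 55%.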

Compound 4, a percentage reported as activity, at one dose (the size of the read-out at that dose, not a potency): 75%
Beside the measured number, compound 4's estimate is 50 percentage points below it; measured number above the stated range.
By their numbers in this assay, from the lowest: compounds 1 and 3 (each within the scatter of the next); then compound 4; then compound 2.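

Methyl in place of methoxy on this saturated chain carbon brings a number 50 percentage points higher from compound 1 to compound 4 (beyond the scatter) in this assay and so shows that the read-out moves with this side chain as well as with the aromatic ring. Among the compounds shown here, this is the first measured step at this carbon, and it shows that methoxymethyl to ethyl is not a neutral exchange. Nothing available accounts for the size of this step.

From the compounds shown here alone, whether a longer chain such as propyl, or an amine on this carbon, would raise or lower the read-out stays open. Also open, going by these compounds, is whether the same change would carry over to the core with chloro on the aromatic ring.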